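Notes on the step from cyano to bromo

The compounds below may be only part of what the source reports. "The series", "measured", "known", "first", "only" and "open" are said of these compounds alone.

Measured in a toxicity assay on THP-1 cells (Homo sapiens) for inhibition; a lower number here means that less compound is tolerated, a higher number that more compound is tolerated:
- compound 1 `Cn1c(-c2ccc(Cl)cc2)cnc1NC(=O)c1ccc(F)cc1`: 37000 nM
- compound 2 `Cn1c(-c2cccc(C#N)c2)cnc1NC(=O)c1ccc(F)cc1`: > 100000 nM (a limit, not a number)

Compound 2 has only a limit to show: the limit of > 100000 nM in this assay, at which 1 of the 2 values shown sits. Any step away from it can therefore be read only against that limit.

The next structure is compound 3 `Cn1c(-c2cccc(Br)c2)cnc1NC(=O)c1ccc(F)cc1`, with bromo in place of cyano on an aromatic carbon. Among the compounds with values here, one measured step bears on this change: an at least 2.7-fold higher number from compound 1 to compound 2 (0.43 log units; beyond the scatter). That step changes the group and its place on the ring together, so it gives only a rough guide. Within the data shown here, compound 3 gives up the cyano group that compound 2 gained in that step, and the only measured number nearby is that of compound 1 at 37000 nM. A lower number in this assay is therefore expected, of roughly the size of that step reversed. The expected change is an at least 2.5-fold lower number from compound 2 to compound 3 (0.39 log units; beyond the scatter). For compound 3 the estimated value is 40000 nM, with an expected range of 15000 nM to 100000 nM.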

Compound 3, half-maximal cytotoxic concentration: > 50000 nM
Compound 3 ended at the assay's limit; the forecaster's own chance of this, stated with the estimate: 20%; middle value at least 1.2-fold (0.09 log units) away from the limit.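

In this assay compound 3 gives only a limit, not a number: the limit of > 50000 nM in this assay, at which 1 of the 3 values shown sits.

Compound 2 also gives only a limit, so the change from cyano to bromo at this place cannot be read, and no order between the two compounds can be stated; what compound 3 adds is that a limit is reached here without the cyano group. Against the one measured compound, the record shows an at least 1.3-fold higher number from compound 1 to compound 3 (0.13 log units; that floor lies within the scatter), so 3-bromophenyl in place of 4-chlorophenyl is not shown to differ beyond the scatter, although the true step may be larger than this floor.

Both steps from compound 1 change the group and its place on the ring together, which leaves the contribution of each unseparated, and a measured number for either compound 2 or compound 3 would be needed to rank them. From the compounds shown here alone, it also remains open how an amine or a carboxylic acid at this place on the ring would read in this assay.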